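Fluoro to chloro exchange on two related cores

This account rests on a few compounds, and the source may have more. Where it says the series, first, only, none or still open, it means among the compounds named here.

Compound 1 `O=C1C=C(C(O)c2ccc(Cl)cc2)C(=O)c2ccccc21` and compound 2 `O=C1C=C(C(O)c2ccc(F)cc2)C(=O)c2ccccc21` share one core; compound 3 `O=C(C1=CC(=O)c2ccccc2C1=O)c1cccc(F)c1` and compound 4 `O=C(C1=CC(=O)c2ccccc2C1=O)c1cccc(Cl)c1` share another. How the two cores differ is not broken down here. In a functional assay on WHCO1 cells (Homo sapiens) for cytotoxicity, read by MTT assay, with a stated time of 24 h (on this read-out lower numbers stand for stronger inhibition and higher numbers for weaker inhibition), compound 1 gives 3000 nM and compound 2 gives 5100 nM; the step of a 1.7-fold lower number from compound 2 to compound 1 (0.23 log units; within the scatter) marks (chloro in place of fluoro on an aromatic carbon), placed para to a large group. Compound 3 gives 94800 nM in this assay, the highest number of the three. Compound 4 carries chloro in place of fluoro on an aromatic carbon, placed meta to a large group, so the same kind of change, not the same. Since a 1.7-fold lower number from compound 2 to compound 1 (0.23 log units; within the scatter) stayed within the scatter, the step from compound 3 to compound 4 is expected to be small, a 1.6-fold lower number from compound 3 to compound 4 (0.20 log units; within the scatter). Compound 4 is accordingly estimated at 60000 nM, with a range from 25000 nM to 150000 nM.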

Compound 4, half-maximal inhibitory concentration: 94800 nM
Beside the measured number, compound 4's estimate is 1.6-fold (0.20 log units) below it; measured number inside the range.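

In this assay, the second core gives this step for chloro in place of fluoro: no change at the digits printed from compound 3 to compound 4 (within the scatter). Set beside the first core, the exchange carries over with no difference that can be told apart: the same change on two cores in this assay, a 1.7-fold lower number (0.23 log units; within the scatter) from compound 2 to compound 1 and no change at the digits printed (within the scatter) from compound 3 to compound 4, 1.7-fold (0.23 log units) apart, within the scatter of two such steps. This rests on a single pair per core, and the placement on the ring differs between the pairs, so it does not separate an effect of the core from one of placement, nor does it show that the exchange would stay as small on any further core.

Open, on these data alone, is whether an amine, a carboxylic acid or a methoxy at these places would move the number. As far as these compounds go, whether bromo would track chloro also remains open.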